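Removing one methoxy group from compound 2: what to expect

A few compounds are considered here, and "the series" means these few. Any claim that something is new, unique, unknown or untested is made for them only; others in the source may bear on it.

Compounds measured in a functional assay on MDA-MB-231 cells (Homo sapiens) for cytotoxicity, read by MTT assay; a higher number here means a weaker inhibitor, a lower number a stronger inhibitor:
- compound 1, `Oc1cc(O)cc(-c2cn(-c3ccc(OC(F)(F)F)cc3)nn2)c1`: > 10000 nM, a limit of the assay and not a number
- compound 2, `COc1cc(-n2cc(-c3ccc(N)cc3)nn2)cc(OC)c1OC`: > 10000 nM, likewise a limit of the assay

Compound 2 stands only at a limit in this assay; no number is known for it. The same holds for compound 1, so the whole set of values shown sits at the limit of > 10000 nM in this assay, at which 2 of the 2 values shown sit. Among the compounds with values here, no step between measured compounds can be computed, and nothing in these two values tells how any change to compound 2 would move its value.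

Compound 3, `COc1ccc(-n2cc(-c3ccc(N)cc3)nn2)cc1OC`, differs from compound 2 in one place: hydrogen in place of methoxy on an aromatic carbon. With both values known only as limits, there is no ground for expecting a step in this assay in either direction beyond the scatter; the plain expectation is that compound 3 stays at the limit as well. The account therefore estimates for compound 3 a value of 15000 nM, with a range of 5000 nM to 50000 nM, which corresponds to an expected step that the limit leaves unreadable from compound 2 to compound 3. Whether compound 3 in fact gives a number is what the measurement will show.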

Compound 3, half-maximal inhibitory concentration: > 10000 nM
Compound 3: only a limit was reported; the forecaster's own chance of this, stated with the estimate: 80%; the middle value does not contradict the limit.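

Within the data shown here, compound 3, like compound 2, is known in this assay only as a limit and not as a number, so no step from compound 2 to compound 3 can be read. All the compounds shown stand at the same limit: the limit of > 10000 nM in this assay, at which 3 of the 3 values shown sit. They leave open how far the methoxy group matters, and which change to the shared core would give a measurable value in this assay.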